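From piperidin-1-yl to benzyl: working notes on compound 4

The source may report more compounds than this note shows. Statements on the series, on what has been measured and on what is new or still open speak of the compounds shown alone.

Of the compounds shown here, three on the shared core have been measured in a functional assay on MCF7 cells (Homo sapiens) for inhibition, read by MTT assay, with a stated time of 48 h, tested at 10 uM; a lower number here means less inhibition of growth, a higher number more inhibition of growth at the concentration tested. Compound 1 (`Cc1cc(=O)c2c(O)cc(OCc3ccc([N+](=O)[O-])cc3)c([C@H]3CCN(C)C[C@H]3O)c2o1`) gives 39% and compound 2 (`Cc1cc(=O)c2c(O)cc(O)c([C@H]3CCN(C)C[C@H]3OC(=O)c3ccco3)c2o1`) gives 20% in this series. Compound 3 (`Cc1cc(=O)c2c(O)c(CN3CCC(N4CCCCC4)CC3)c(O)c([C@H]3CCN(C)C[C@H]3O)c2o1`) gives 25% and is level with compound 2 within the scatter, while compound 1 stands higher, beyond the scatter.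

Compound 4 (`Cc1cc(=O)c2c(O)c(CN3CCC(Cc4ccccc4)CC3)c(O)c([C@H]3CCN(C)C[C@H]3O)c2o1`) differs from compound 3 by benzyl in place of piperidin-1-yl on a saturated ring carbon. Going by the values given here, no measured pair differs in only one place, so this exchange has no direct precedent. Compound 3 at 25% is therefore the only starting point for the expectation. A small rise is expected in this assay, with an estimated a number 7 percentage points higher from compound 3 to compound 4 (within the scatter) that stays within the scatter. In this assay compound 4 is estimated at 32% with a range of 15% to 52% as the working figures.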

Compound 4, percent growth inhibition at one concentration: 17%
The estimate for compound 4 lay 15 percentage points above the measured number; measured number inside the range.
By their numbers in this assay, from the lowest: compounds 4, 2 and 3 (each within the scatter of the next); then compound 1.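

The series now holds its first one-place step, and in this assay benzyl in place of piperidin-1-yl on a saturated ring carbon reads a number 8 percentage points lower from compound 3 to compound 4 (within the scatter) on this exchange. At this place, three ring bonds from the ring nitrogen, a six-membered aromatic ring of carbon only can therefore stand in for a non-aromatic ring with a hydrogen-bond acceptor, with the number staying within the scatter. No measurement at hand bears on the reason for this result.

On these data alone, whether an amine such as dimethylamino, a carboxylic acid or a longer chain on this ring carbon would move the number beyond the scatter remains open. Compound 1 and compound 2 differ from compound 4 in more than one place, so the steps between them cannot be read.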